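A pyridin-4-yl in place of pyridin-2-yl

This account rests on a few compounds, and the source may have more. Where it says the series, first, only, none or still open, it means among the compounds named here.

Values measured in a functional assay on HepG2 cells (Homo sapiens) for inhibition, read by MTT assay, with a stated time of 72 h (a lower number here means a stronger inhibitor, a higher number a weaker inhibitor), for three compounds:
- Compound 1 `Cc1ccccc1-c1cc(C(=O)N2CCC3(CC2)CC(=O)c2nn(C(C)(C)C)cc2O3)c2ccccc2n1` gives > 10000 nM as a limit of the assay
- Compound 2 `COc1ccc(-c2cc(C(=O)N3CCC4(CC3)CC(=O)c3nn(C(C)(C)C)cc3O4)c3ccccc3n2)cc1` gives 2780 nM
- Compound 3 `CC(C)(C)n1cc2c(n1)C(=O)CC1(CCN(C(=O)c3cc(-c4ccccn4)nc4ccccc34)CC1)O2` gives 1500 nM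

Compound 3 has one comparison with a number on both sides, a 1.9-fold lower number from compound 2 to compound 3 (0.27 log units; within the scatter), so it stands level with compound 2 within the scatter. Its other comparison, an at least 6.6-fold lower number from compound 1 to compound 3 (0.82 log units; beyond the scatter), rests on a limit, as does an at least 3.5-fold lower number from compound 1 to compound 2 (0.55 log units; beyond the scatter).

Compound 4 `CC(C)(C)n1cc2c(n1)C(=O)CC1(CCN(C(=O)c3cc(-c4ccncc4)nc4ccccc34)CC1)O2` carries pyridin-4-yl in place of pyridin-2-yl on an aromatic carbon, with the same atoms joined differently (pyridin-4-yl in place of pyridin-2-yl on an aromatic carbon). Going by the values given here, no measured step makes this exact exchange. The closest one swaps 4-methoxyphenyl for pyridin-2-yl and stays within the scatter, a 1.9-fold lower number from compound 2 to compound 3 (0.27 log units; within the scatter). The larger steps all start from the 2-methylphenyl of compound 1. A step beyond the scatter is therefore not expected in this assay, and no firm direction is expected either. The estimated step is a 1.2-fold higher number from compound 3 to compound 4 (0.08 log units; within the scatter). For compound 4 the expected value is 1800 nM, with an estimated range from 600 nM to 5500 nM.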

Compound 4, half-maximal inhibitory concentration: 380 nM
Compound 4: middle estimate off by 4.7-fold (0.68 log units), on the high side, outside the stated range (below it).
By their numbers in this assay, from the lowest: compound 4; then compounds 3 and 2 (each within the scatter of the next). At a limit, above all of these: compound 1.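

In this assay, the same atoms joined differently give a 3.9-fold lower number from compound 3 to compound 4 (0.60 log units; beyond the scatter), so at this position the place of the nitrogen in the pyridine ring matters, and not only the presence of a pyridine. The pyridine alone does not account for the result: the pyridin-2-yl of compound 3 stayed within the scatter of the 4-methoxyphenyl of compound 2, while pyridin-4-yl gives a 7.3-fold lower number from compound 2 to compound 4 (0.86 log units; beyond the scatter). Compound 1 gives only a limit of the assay, so an at least 26-fold lower number from compound 1 to compound 4 (1.42 log units; beyond the scatter) is a bound and not a measured size: the limit of > 10000 nM in this assay, at which 1 of the 4 values shown sits.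

The compounds shown leave open whether pyridin-3-yl would fall with compound 3 or with compound 4. They also leave open whether an amine or a carboxylic acid on the pyridin-4-yl ring would keep this step.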